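From methoxy to ethoxy at the assay limit

A few compounds are considered here, and "the series" means these few. Any claim that something is new, unique, unknown or untested is made for them only; others in the source may bear on it.

Measured in a functional assay on HeLa cells (Homo sapiens) for antiproliferative activity, read by MTT assay, with a stated time of 72 h; on this read-out higher numbers stand for weaker inhibition and lower numbers for stronger inhibition:
compound 1 `COc1cc(-n2ncnc2-c2ccccc2)cc(OC)c1OC`: > 10000 nM (a limit)
compound 2 `COc1ccccc1-c1ncnn1-c1cc(OC)c(OC)c(OC)c1`: > 10000 nM (a limit)

Compound 2 has no exact number on this scale. Its entry of > 10000 nM is a limit of the assay, not a measured potency. The same is true of compound 1, so the whole record so far is the limit of > 10000 nM in this assay, at which 2 of the 2 values shown sit.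

The next compound, compound 3 `CCOc1ccccc1-c1ncnn1-c1cc(OC)c(OC)c(OC)c1`, keeps the shared core and extends the methoxy of compound 2 to an ethoxy: methyl in place of hydrogen on a saturated chain carbon bound to an oxygen on an aromatic ring.

Among the measured compounds shown here, only one measured step bears on this change: a step that the two limits leave unreadable from compound 1 to compound 2. That step put the methoxy in place, but its size cannot be read, so it offers no measured effect to carry forward. Nothing yet shows that this part of the structure can move the result in this assay, so no step beyond the usual scatter is expected, in either direction. The expected step is a step that the limit leaves unreadable from compound 2 to compound 3. Compound 3 is estimated at 15000 nM, with an expected range of 5000 nM to 40000 nM. The likeliest report for compound 3 is again only a limit.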

Compound 3, half-maximal inhibitory concentration: > 10000 nM
Compound 3 ended at the assay's limit; the forecaster's own chance of this, stated with the estimate: 85%; the middle value does not contradict the limit.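

No step among compound 1, compound 2 and compound 3 can be read, because each entry is a limit and not a measured potency: the limit of > 10000 nM in this assay, at which 3 of the 3 values shown sit.

The compounds shown leave open whether methoxy or ethoxy makes any difference in this assay, and what change to the shared core would bring a compound to an exact value there.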